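A fluoro for a methyl near the assay limit

The compounds below may be only part of what the source reports. "The series", "measured", "known", "first", "only" and "open" are said of these compounds alone.

Compound 1 `Cc1ccc2nc(-c3ccccc3N(C)C)[nH]c(=O)c2c1`: 26700 nM
Compound 2 `Cc1ccc2nc(-c3ccccc3C(F)(F)F)[nH]c(=O)c2c1`: > 50000 nM (a limit)
Compound 3 `Cc1ccc2nc(-c3ccccc3C)[nH]c(=O)c2c1`: > 50000 nM (a limit)

In a functional assay on T47D cells (Homo sapiens) for cytotoxicity, read by MTT assay, with a stated time of 2 days (on this read-out higher numbers stand for weaker inhibition and lower numbers for stronger inhibition), compound 3 gives > 50000 nM. This is a limit and not a number, so compound 3 has no exact place on the scale.

Compound 4 `Cc1ccc2nc(-c3ccccc3F)[nH]c(=O)c2c1` keeps the shared core and changes one group: fluoro in place of methyl on an aromatic carbon. The change is fluoro in place of methyl on an aromatic carbon, ortho to a large group.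

Among the compounds with values here, three measured steps bear on it. Replacing dimethylamino gave an at least 1.8-fold higher number from compound 1 to compound 3 (0.27 log units; that floor lies within the scatter), and a second replacement gave an at least 1.8-fold higher number from compound 1 to compound 2 (0.27 log units; that floor lies within the scatter). The remaining pair shows a step that the two limits leave unreadable from compound 2 to compound 3. Most of the evidence sits at one ceiling: the limit of > 50000 nM in this assay, at which 2 of the 3 values shown sit.

Neither step from compound 1 is shown to exceed the scatter, and no measured step covers fluoro. From the compounds shown here alone, no step beyond the scatter is therefore expected in this assay, and the direction stays open. The expected change is a number no higher from compound 3 to compound 4 (the limit leaves the size open). For compound 4 the estimated value is 50000 nM, with an expected range of 25000 nM to 100000 nM.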

Compound 4, half-maximal inhibitory concentration: > 50000 nM
Compound 4: no number, only a limit; the forecaster's own chance of this, stated with the estimate: 70%; the middle value lies on the limit itself.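

In this assay compound 4 gives > 50000 nM, a limit and not a number, so fluoro is now the third group on this aromatic carbon, ortho to a large group, that yields no exact value. Within the data shown here, the one step that can be read is an at least 1.8-fold higher number from compound 1 to compound 4 (0.27 log units; that floor lies within the scatter), which does not set fluoro apart from dimethylamino, and the steps linking compound 4 to compound 2 and compound 3 cannot be read. Swapping methyl for fluoro thus adds one more compound to a single ceiling: the limit of > 50000 nM in this assay, at which 3 of the 4 values shown sit.

From the compounds shown here alone, how far compound 2, compound 3 and compound 4 lie from one another remains unknown, so the real effect of fluoro in place of methyl stays open. Also open, going by these compounds, is whether a hydroxyl group, a carboxylic acid or a primary amine at this position would give a value clearly apart from that of compound 1.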